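A few compounds are considered here, and "the series" means these few. Any claim that something is new, unique, unknown or untested is made for them only; others in the source may bear on it.

The measured compounds in a physicochemical assay for solubility, read by HPLC, with a stated time of 4 h, at pH 2; a lower number here means a less soluble compound, a higher number a more soluble compound:

Compound 1 `CCNC(=O)c1cc(N)c(Nc2ccc(C#N)cc2)cc1Oc1c(C)cc(/C=C/C#N)cc1C` gives 69.4 ug/mL.
Compound 2 `Cc1cc(/C=C/C#N)cc(C)c1Oc1cc(Nc2ccc(C#N)cc2)c(N)cc1C(=O)NCCC(F)F` gives 57.6 ug/mL.
Compound 3 `Cc1cc(/C=C/C#N)cc(C)c1Oc1cc(Nc2ccc(C#N)cc2)c(N)cc1C(=O)OCCC#N` gives 0.94 ug/mL.

Compound 1 stands highest of the three numbers. Its nearest neighbour is compound 2, and that step, a 1.2-fold lower number from compound 1 to compound 2 (0.08 log units; within the scatter), lies within the scatter. The furthest is compound 3, reached by a 74-fold lower number from compound 1 to compound 3 (1.87 log units; beyond the scatter), with the matching step a 61-fold lower number from compound 2 to compound 3 (1.79 log units; beyond the scatter) of like size.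

Compound 4 `CNC(=O)c1cc(N)c(Nc2ccc(C#N)cc2)cc1Oc1c(C)cc(/C=C/C#N)cc1C` differs from compound 1 by hydrogen in place of methyl on a saturated chain carbon bound to an amide-type nitrogen. Within the data shown here, only one measured step touches the group on the amide-type nitrogen, namely a 1.2-fold lower number from compound 1 to compound 2 (0.08 log units; within the scatter), and it stayed within the scatter. The two large steps, a 74-fold lower number from compound 1 to compound 3 (1.87 log units; beyond the scatter) and a 61-fold lower number from compound 2 to compound 3 (1.79 log units; beyond the scatter), both come from putting 2-cyanoethoxy on the carbonyl carbon in place of an amino group, which is not what changes here. Among the measured compounds shown here, no measured step shows the loss of a single methyl from the chain.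

Compound 4 is therefore expected to show no step beyond the scatter, a 1.2-fold higher number from compound 1 to compound 4 (0.06 log units; within the scatter). The estimate for compound 4 is 80 ug/mL, with a range from 35 ug/mL to 180 ug/mL.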

Compound 4, solubility: 44.7 ug/mL
Beside the measured number, compound 4's estimate is 1.8-fold (0.25 log units) above it; measured number inside the range.
By their numbers in this assay, from the lowest: compound 3; then compounds 4, 2 and 1 (each within the scatter of the next).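

In this assay, taking the chain on the amide-type nitrogen from ethylamino down to methylamino gives a 1.6-fold lower number from compound 1 to compound 4 (0.19 log units; within the scatter), so the loss of this single methyl stays within the scatter. The exchange of the whole group on that nitrogen, seen in a 1.3-fold lower number from compound 2 to compound 4 (0.11 log units; within the scatter), stays within it as well, while methylamino in place of 2-cyanoethoxy on the carbonyl carbon gives a 48-fold higher number from compound 3 to compound 4 (1.68 log units; beyond the scatter), so the large gap to compound 3 also holds for this third amide. Nothing given here accounts for these numbers.

The compounds shown leave open whether a longer chain, or an amine or a carboxylic acid carried on the chain, would also stay within the scatter. They also leave open which part of 2-cyanoethoxy, its oxygen or its nitrile, goes with the low number of compound 3.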